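A Pyridine Swap on an Open-Chain Dithiol Amide

The source may hold more compounds than are shown below. What is called first, only, known or untested is meant among the compounds shown, and "the series" means these compounds.

Measured so far in a functional assay on KB cells (Homo sapiens) for inhibition, read by MTT assay, with a stated time of 24 h, tested at 0.1 ug/mL (on this read-out lower numbers stand for less inhibition of growth and higher numbers for more inhibition of growth at the one concentration tested), on two compounds:
Compound 1 (`O=C(CCCCC1CCSS1)Nc1ccccn1`) gives "not active" (no number reported)
Compound 2 (`O=C(CCCCC(S)CCS)Nc1ccccc1`) gives 9.49%

Going by the values given here, compound 2 gives 9.49% and is the only compound so far with an actual number, so there is no numerical scale to rank it on. Compound 1 is reported as "not active" (no number reported) without a figure, so no step can be read between the two.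

The next compound is compound 3 (`O=C(CCCCC(S)CCS)Nc1ccccn1`). It has pyridin-2-yl in place of phenyl on an amide-type nitrogen, and the rest of the structure stays as in compound 2.

Among the compounds with values here, no measured pair shows this swap on its own. Within the data shown here, compound 1 carries the same pyridin-2-yl, but its core differs, so it sets no size for the step. That leaves compound 2 (9.49%) as the closest guide. No step beyond the usual scatter is expected in this assay in either direction, and the estimated change is a number 1.5 percentage points higher from compound 2 to compound 3 (within the scatter) as a best guess. Compound 3 is expected at 11% with an estimated range from 2% to 25% in this read-out.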

Compound 3, percent growth inhibition at one concentration: "not active" (no number reported)
Compound 3 has no reported number here; no gap can be computed for the estimate.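

In this assay compound 3 gives "not active" (no number reported) and only compound 2 carries a number, so no step can be read from compound 2 to compound 3. No other measurement shown bears on this result. The compounds shown leave open how large the effect of pyridin-2-yl in place of phenyl is in this assay.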